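The compounds below may be only part of what the source reports. "The series", "measured", "known", "first", "only" and "open" are said of these compounds alone.

For the measured compounds named here, compound 2 `CN1CCN(CCCOc2cccc3nc(Nc4cc(Cl)cc(Cl)c4)ccc23)CC1` gives 3720 nM in a functional assay on cells (Panel NCI-60 (60 carcinoma cell lines), Homo sapiens) for inhibition, read by sulforhodamine B assay, with a stated time of 48 h (a lower number here means a stronger inhibitor of growth, a higher number a weaker inhibitor of growth), which puts it at the top of the two numbers so far, though its neighbour compound 1 `CN1CCN(CCCOc2cccc3nc(Nc4ccc(Cl)c(C(F)(F)F)c4)ccc23)CC1` sits within the scatter of it with 3470 nM. Going by the values given here, the only step recorded among the measured pair, a 1.1-fold higher number from compound 1 to compound 2 (0.03 log units; within the scatter), exchanges one substitution pattern of the aniline ring for another without moving the number beyond the scatter. Among the compounds with values here, compound 3 `CN1CCN(CCCOc2cccc3nc(Nc4cccc(Cl)c4)ccc23)CC1` differs from compound 2 by hydrogen in place of chloro on an aromatic carbon, a loss of one of the two chloro groups rather than a swap of pattern, so no measured step matches it directly. Given that the one aryl change on record, from compound 1 to compound 2, stayed within the scatter, compound 3 is expected to show at most a modest step in this assay, leaning toward a somewhat higher number, a 1.2-fold higher number from compound 2 to compound 3 (0.08 log units; within the scatter). Compound 3 is therefore estimated at 4500 nM, with a range from 2200 nM to 9500 nM.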

Compound 3, concentration for total growth inhibition: 4170 nM
Compound 3: middle estimate off by 1.1-fold (0.03 log units), on the high side; the range from low to high includes it.
By their numbers in this assay, from the lowest: compounds 1, 2 and 3 (each within the scatter of the next).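

Exchanging one chloro group of the 3,5-dichlorophenyl group for hydrogen on this aromatic carbon gives a step that stays within the scatter in this assay (a 1.1-fold higher number from compound 2 to compound 3 (0.05 log units; within the scatter)). The larger exchange of 4-chloro-3-(trifluoromethyl)phenyl for 3-chlorophenyl also stays within the scatter (a 1.2-fold higher number from compound 1 to compound 3 (0.08 log units; within the scatter)), so the three aryl groups on the nitrogen cannot be told apart by this read-out, and no compound shown goes against that. Nothing available bears on why these aryl changes give such small steps.

From the compounds shown here alone, it remains open whether hydrogen in place of the remaining chloro group would give a step beyond the scatter. The same holds for an amine or a carboxylic acid on this ring, or a longer chain between the core and the far ring.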